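Cytotoxicity notes: biaryl change from compound 3 to compound 4

A few compounds are considered here, and "the series" means these few. Any claim that something is new, unique, unknown or untested is made for them only; others in the source may bear on it.

Measured compounds in an ADME assay on HEK293 cells (Homo sapiens) for cytotoxicity, read by CellTiter-Glo and resazurin assay, with a stated time of 72 h; on this read-out higher numbers stand for an effect only at larger amounts of compound and lower numbers for an effect already at smaller amounts:
- compound 1 `CC(C)N(Cc1cccc(OCCCCCC(=O)O)c1)C(=O)c1ccc(-c2ccco2)cc1` gives > 26000 nM, a limit of this assay.
- compound 2 `CC(C)N(Cc1cccc(OCCCCCC(=O)O)c1)C(=O)c1ccc(-c2cccc(O)c2)cc1` gives > 26000 nM, a limit of this assay.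
- compound 3 `CCOC(=O)CCCCCOc1cccc(CN(C(=O)c2ccc(-c3ccco3)cc2)C(C)C)c1` gives > 26000 nM, a limit of this assay.

Compound 3 therefore stands at the limit of > 26000 nM in this assay, at which 3 of the 3 values shown sit, with no number of its own. The two steps that touch the set, a step that the two limits leave unreadable from compound 1 to compound 2 and a step that the two limits leave unreadable from compound 1 to compound 3, give no readable size. Compound 4 `CCOC(=O)CCCCCOc1cccc(CN(C(=O)c2ccc(-c3ccc(Cl)c(Cl)c3)cc2)C(C)C)c1` differs from compound 3 by 3,4-dichlorophenyl in place of furan-2-yl on an aromatic carbon. Within the data shown here, no measured step bears on this change, so no direction beyond the scatter is expected; the step of an at least 1.0-fold lower number from compound 3 to compound 4 (0.01 log units; that floor lies within the scatter) is an estimate only. Compound 4 is expected at 25000 nM, within 8000 nM to 60000 nM, most likely again a limit in this assay.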

Compound 4, half-maximal effective concentration: > 26000 nM
Compound 4: no number, only a limit; the forecaster's own chance of this, stated with the estimate: 65%; middle value at least 1.0-fold (0.01 log units) away from the limit.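

Compound 3 and compound 4 both give only a limit in this assay, so no step between them can be read: the limit of > 26000 nM in this assay, at which 4 of the 4 values shown sit.

The compounds shown leave open whether 3,4-dichlorophenyl in place of furan-2-yl changes the read-out at all, since none has a number of its own.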